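The source may report more compounds than this note shows. Statements on the series, on what has been measured and on what is new or still open speak of the compounds shown alone.

Compound 3, `COc1cc2c(Nc3ccc(NC(=O)Nc4ccccc4)cc3)ncnc2cc1OCCCN1CCN(C)CC1`, belongs to a small set of anilinoquinazoline ureas examined in a functional assay on NCI-H460 cells (Homo sapiens) for antiproliferative activity, read by MTT assay, with a stated time of 48 h; on this read-out higher numbers stand for weaker inhibition and lower numbers for stronger inhibition. Its parent, compound 1, `COc1cc2c(Nc3ccc(NC(=O)Nc4ccccc4)cc3)ncnc2cc1OCc1ccccc1`, returns only the limit of > 50000 nM in this assay, a limit rather than a number, which is also noted as the limit of > 50000 nM in this assay, at which 1 of the 3 values shown sits. Compound 2, `COc1cc2c(Nc3ccc(NC(=O)Nc4ccc(C)cc4)cc3)ncnc2cc1OCc1ccccc1`, gives 25400 nM in this assay, a change described by an at least 1.9-fold lower number from compound 1 to compound 2 (0.29 log units; that floor lies within the scatter). Compound 3 itself gives 28400 nM in this assay, the step being an at least 1.7-fold lower number from compound 1 to compound 3 (0.24 log units; that floor lies within the scatter). Among the numbers shown, compound 3 and compound 2 lie within the scatter of each other, and the only remaining value, that of compound 1, is a limit.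

Compound 4, `COc1cc2c(Nc3ccc(NC(=O)Nc4ccccc4)c(Cl)c3)ncnc2cc1OCCCN1CCN(C)CC1`, differs from compound 3 by chloro in place of hydrogen on an aromatic carbon. Neither measured step touches this position: one alters a methyl on the terminal phenyl of the urea and the other exchanges the ether side chain, and both stay within the scatter. Going by the values given here, no step therefore bears directly on the chloro substitution, and little movement is expected. The account expects a 1.1-fold lower number from compound 3 to compound 4 (0.06 log units; within the scatter) for compound 4. Compound 4 is accordingly estimated at 25000 nM, with a range from 8000 nM to 60000 nM.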

Compound 4, half-maximal inhibitory concentration: 33000 nM
Compound 4: middle estimate off by 1.3-fold (0.12 log units), on the low side, within the range that was stated.
By their numbers in this assay, from the lowest: compounds 2, 3 and 4 (each within the scatter of the next). At a limit, above all of these: compound 1.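

In this assay, chloro in place of hydrogen on the aromatic carbon ortho to the (phenylcarbamoyl)amino group gives a 1.2-fold higher number from compound 3 to compound 4 (0.07 log units; within the scatter), which lies within the scatter. Going by these compounds alone, the earlier steps changed only the terminal phenyl of the urea and the ether side chain, so this is the first reading on the ring that carries the (phenylcarbamoyl)amino group, and it shows that a single chlorine atom at this carbon leaves the number indistinguishable from that of the hydrogen parent. The information at hand gives no cause for this result, and nothing measured here bears on the chloro group.

From the compounds shown here alone, whether an amine, a methoxy group or a carboxylic acid at this same carbon would also leave the number unmoved remains open. So does whether chloro on the terminal phenyl of the urea would give a step beyond the scatter.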